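Moving the methoxy group: compound 2 to compound 3

The source may report more compounds than this note shows. Statements on the series, on what has been measured and on what is new or still open speak of the compounds shown alone.

In a functional assay on L1210 cells (Mus musculus) for antiproliferative activity, read by MTT assay, with a stated time of 72 h (a lower number here means a stronger inhibitor, a higher number a weaker inhibitor), the values are:
- compound 1 `COc1ccc(C2=NN(C(C)=O)C(c3cccc([N+](=O)[O-])c3)O2)cc1` gives 47000 nM
- compound 2 `COc1ccc(C2=NN(C(C)=O)C(c3ccc(OC)cc3)O2)cc1` gives > 100000 nM (a limit of the assay, not a number)

Compound 2 stands at > 100000 nM as a limit and has no number. Compound 3 `COc1ccc(C2=NN(C(C)=O)C(c3cccc(OC)c3)O2)cc1` carries 3-methoxyphenyl in place of 4-methoxyphenyl on a saturated ring carbon, and 3-methoxyphenyl in place of 4-methoxyphenyl on a saturated ring carbon is the whole change. Among the compounds with values here, for this assay no step between measured compounds differing in one place is available, so the expected size rests on little. Compound 1 at 47000 nM shows that a number can be read on the shared core. A small step towards stronger inhibition is expected, perhaps none beyond the scatter, and the estimate means an at least 1.5-fold lower number from compound 2 to compound 3 (0.18 log units; that floor lies within the scatter) as an expected change. A second reading at the limit is also possible. Compound 3 is estimated at 65000 nM with an expected range from 30000 nM to 100000 nM.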

Compound 3, half-maximal inhibitory concentration: 41000 nM
Beside the measured number, compound 3's estimate is 1.6-fold (0.20 log units) above it; the measured number falls inside the stated range.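

In this assay, 3-methoxyphenyl in place of 4-methoxyphenyl on the saturated ring carbon gives an at least 2.4-fold lower number from compound 2 to compound 3 (0.38 log units; beyond the scatter), so moving the methoxy group on the aromatic ring changes the read-out with the same atoms present. With the substituent kept in the 3-position of the ring, methoxy in place of nitro gives a 1.1-fold lower number from compound 1 to compound 3 (0.06 log units; within the scatter), so the two groups cannot be told apart in this assay. The full size of the step from the 4-methoxyphenyl compound remains unknown because compound 2 has a limit and not a number: the limit of > 100000 nM in this assay, at which 1 of the 3 values shown sits.

As far as these compounds go, whether an amine or a carboxylic acid in place of the methoxy group of compound 3 would keep activity at this level remains open. The same holds for a longer chain, such as ethoxy, at that position.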